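The source may hold more compounds than are shown below. What is called first, only, known or untested is meant among the compounds shown, and "the series" means these compounds.

Working notes on the series in a functional assay (Oryctolagus cuniculus) for inhibition of platelet-activating factor receptor (Cavia porcellus); a lower number here means a stronger inhibitor, a higher number a weaker inhibitor.

Three esters of the shared core have numbers. Compound 1 `CCCC(=O)OCC1CN(C(=O)c2cc(OC)c(OC)c(OC)c2)CCN1C(=O)c1cc(OC)c(OC)c(OC)c1` gives 420 nM. Compound 2 `CCCCCC(=O)OCC1CN(C(=O)c2cc(OC)c(OC)c(OC)c2)CCN1C(=O)c1cc(OC)c(OC)c(OC)c1` gives 290 nM. Compound 3 `COc1cc(C(=O)N2CCN(C(=O)c3cc(OC)c(OC)c(OC)c3)C(COC(=O)C3CCCCC3)C2)cc(OC)c1OC` gives 290 nM. The steps among them are small: a 1.4-fold lower number from compound 1 to compound 2 (0.16 log units; within the scatter), a 1.4-fold lower number from compound 1 to compound 3 (0.16 log units; within the scatter), and no change at the digits printed from compound 2 to compound 3 (within the scatter). Compound 3 therefore stands level with compound 2, the two together holding the lowest numbers of the three, with compound 1 the furthest away and still within the scatter.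

The next compound, compound 4 `COc1cc(C(=O)N2CCN(C(=O)c3cc(OC)c(OC)c(OC)c3)C(COC(=O)NC(C)(C)C)C2)cc(OC)c1OC`, differs from compound 3 in one place: (tert-butyl)amino in place of cyclohexyl on a carbonyl carbon. Among the compounds with values here, the steps that bear on this position are the exchanges on the same carbonyl carbon, a 1.4-fold lower number from compound 1 to compound 3 (0.16 log units; within the scatter) and no change at the digits printed from compound 2 to compound 3 (within the scatter), neither of which moved the number beyond the scatter. Within the data shown here, no measured step brings a nitrogen or a hydrogen-bond donor to this carbonyl carbon, so the present change is not covered directly. On the steps available, no step beyond the scatter is expected here, which is to say compound 3 to compound 4 is estimated as a 1.1-fold higher number from compound 3 to compound 4 (0.04 log units; within the scatter). Compound 4 is thus expected to give about 320 nM, within the range 120 nM to 900 nM.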

Compound 4, half-maximal inhibitory concentration: 130 nM
Estimate against measurement, compound 4: 2.5-fold (0.39 log units) above; the measured number falls inside the stated range.
By their numbers in this assay, from the lowest: compound 4; then compounds 2, 3 and 1 (each within the scatter of the next).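

In this assay this carbonyl carbon first shows a step beyond the scatter with (tert-butyl)amino (a 2.2-fold lower number from compound 3 to compound 4 (0.35 log units; beyond the scatter); a 2.2-fold lower number from compound 2 to compound 4 (0.35 log units; beyond the scatter); a 3.2-fold lower number from compound 1 to compound 4 (0.51 log units; beyond the scatter)), whereas the exchanges among propyl, pentyl and cyclohexyl all stayed within it. All three new steps are modest, yet they place compound 4, the only compound shown with a nitrogen and a hydrogen-bond donor in the group on this carbon, lowest of the four. No measurement shown here accounts for the step.

Open, going by these compounds, is whether the step follows the nitrogen or the branched tert-butyl shape, which tert-butyl or cyclohexylamino on this carbonyl carbon would help separate. Also open, on these data alone, is how the number responds to methylamino or anilino at the same place.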